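Chlorophenyl for Methoxyphenyl Across Two Benzothiazole Cores

This account rests on a few compounds, and the source may have more. Where it says the series, first, only, none or still open, it means among the compounds named here.

Compound 2 `COc1cccc(-c2nn(-c3ccccc3)cc2C(Nc2nc3ccc(OC)cc3s2)c2c(O)ccc3ccccc23)c1` gives 62600 nM in a functional assay on MCF7 cells (Homo sapiens) for antiproliferative activity, read by MTT assay, with a stated time of 48 h; on this read-out higher numbers stand for weaker inhibition and lower numbers for stronger inhibition. Compound 1 `COc1ccc2nc(NC(c3cn(-c4ccccc4)nc3-c3ccc(Cl)cc3)c3c(O)ccc4ccccc34)sc2c1` carries 4-chlorophenyl in place of 3-methoxyphenyl on an aromatic carbon and gives 23700 nM in this assay, which is a step of a 2.6-fold lower number from compound 2 to compound 1 (0.42 log units; beyond the scatter). Compound 3 `COc1cccc(-c2nn(-c3ccccc3)cc2C(Nc2nc3ccc(Cl)cc3s2)c2c(O)ccc3ccccc23)c1` differs from compound 2 in its core by chloro in place of methoxy on an aromatic carbon. In this assay compound 3 gives 36000 nM, a step of a 1.7-fold lower number from compound 2 to compound 3 (0.24 log units; within the scatter). Compound 4 `Oc1ccc2ccccc2c1C(Nc1nc2ccc(Cl)cc2s1)c1cn(-c2ccccc2)nc1-c1ccc(Cl)cc1` has not yet been measured; it differs from compound 3 by 4-chlorophenyl in place of 3-methoxyphenyl on an aromatic carbon. This is the same change as the one from compound 2 to compound 1, made here on the core of compound 3 instead of the core of compound 2, and it occurs twice among these four compounds. Because the change gave a 2.6-fold lower number from compound 2 to compound 1 (0.42 log units; beyond the scatter) on the other core, compound 4 is expected to show a step of about a 2.4-fold lower number from compound 3 to compound 4 (0.38 log units; beyond the scatter) in this assay. The expected number for compound 4 in this assay is 15000 nM, with an estimated range from 7000 nM to 35000 nM. From the compounds shown here alone, the range is kept wide: a single earlier example of this change exists, and its transfer to the core of compound 3 remains untested.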

Compound 4, half-maximal inhibitory concentration: 27500 nM
Compound 4: middle estimate off by 1.8-fold (0.26 log units), on the low side; low and high end bracket the measured number.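

In this assay, 4-chlorophenyl in place of 3-methoxyphenyl gives a 1.3-fold lower number from compound 3 to compound 4 (0.12 log units; within the scatter), and this step does not differ beyond the scatter from the same change on the other core: the same change on two cores in this assay, a 2.6-fold lower number (0.42 log units; beyond the scatter) from compound 2 to compound 1 and a 1.3-fold lower number (0.12 log units; within the scatter) from compound 3 to compound 4, 2.0-fold (0.30 log units) apart, within the scatter of two such steps. Chloro in place of methoxy gives a 1.2-fold higher number from compound 1 to compound 4 (0.06 log units; within the scatter), and this change also reads alike on its two cores: the same change on two cores in this assay, a 1.7-fold lower number (0.24 log units; within the scatter) from compound 2 to compound 3 and a 1.2-fold higher number (0.06 log units; within the scatter) from compound 1 to compound 4, 2.0-fold (0.30 log units) apart, within the scatter of two such steps. Within these four compounds, both changes are therefore compatible with carrying over from one core to the other, but this does not establish a fixed size for either change, as each rests on only two steps and a gap within the scatter does not prove the steps equal.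

The compounds shown leave open how an amine or a carboxylic acid would read on the aromatic carbon that now bears the 4-chlorophenyl or 3-methoxyphenyl group. They also leave open whether these steps hold on any other core or in any read-out other than this assay.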